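A few compounds are considered here, and "the series" means these few. Any claim that something is new, unique, unknown or untested is made for them only; others in the source may bear on it.

Among the compounds with values here, in a functional assay on K562 cells (Homo sapiens) for inhibition, read by sulforhodamine B assay, with a stated time of 48 h (a higher number here means a weaker inhibitor, a lower number a stronger inhibitor), two compounds have numbers so far. Compound 1, `CCC/C=C1\OC(=O)C2=C1CC[C@H]1[C@@H]2[C@@]2(OC(=O)C3=C2CCC=C3)[C@H]1CCC`, gives 46100 nM in this assay. Compound 2, `CCCC[C@]12O[C@@]34CCCC=C3C(=O)O[C@]43[C@@H](CCC)[C@@H]4C=C(C(=O)N1[C@H](C)c1ccccc1)[C@@]32CC4`, gives 5700 nM in this assay. Of these two numbers, compound 2 holds the lower one, and the gap to compound 1 lies beyond the scatter of repeated runs. Compound 3, `CCCC[C@]12O[C@@]34CCCC=C3C(=O)O[C@]43[C@@H](CCC)[C@H]4C=C(C(=O)N1[C@@H](C)c1ccccc1)[C@@]32CC4`, still awaits measurement. Its relation to compound 2 is a matter of configuration alone: the two compounds have the same atoms and bonds and differ only in configuration as drawn: 2 of 7 stereo elements differ; a stereocentre at a saturated ring carbon is drawn S in compound 2 and R in compound 3; a stereocentre at a saturated chain carbon is drawn R in compound 2 and S in compound 3. Within the data shown here, no pair of measured compounds differs in only one place, so there is no earlier step to show what such an inversion of two stereocentres does here. A step of a 1.6-fold higher number from compound 2 to compound 3 (0.20 log units; within the scatter) is expected from compound 2 to compound 3, toward a higher number, and it may still fall within the scatter. On that basis compound 3 is estimated at 9000 nM in this assay, with a range from 2500 nM to 30000 nM.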

Compound 3, half-maximal inhibitory concentration: 5200 nM
Beside the measured number, compound 3's estimate is 1.7-fold (0.24 log units) above it; the measured number falls inside the stated range.
By their numbers in this assay, from the lowest: compounds 3 and 2 (each within the scatter of the next); then compound 1.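

In this assay, the inversion of the saturated ring carbon and the saturated chain carbon together gives a 1.1-fold lower number from compound 2 to compound 3 (0.04 log units; within the scatter). Within the data shown here, this is the first step between two measured compounds, and what it tests is configuration alone, with no group entering or leaving: the fact that compounds 2 and 3 differ only in the configuration as drawn. For this pair, then, the configuration drawn at these two stereocentres does not separate the numbers in this assay.

From the compounds shown here alone, each inversion is seen only together with the other, so whether either one alone would move the number, or whether two opposing effects cancel here, remains open. Also open, going by these compounds, is what an amine, a carboxylic acid or a longer chain on the shared core would do to the number in this assay.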